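From methoxycarbonyl to isopropoxycarbonyl on a shared core

A few compounds are considered here, and "the series" means these few. Any claim that something is new, unique, unknown or untested is made for them only; others in the source may bear on it.

Compound 1 `CC(C)OC(=O)NC1=NC(c2ccccc2F)CN1C`: 30 mg/kg
Compound 2 `COC(=O)NC1=NC(c2ccccc2Cl)CN1C`: 37 mg/kg

Only these two compounds have been measured so far. In a functional assay on the whole organism with Mus musculus as the target (a higher number here means that more compound is needed for the effect, a lower number that less compound is needed), compound 2 reads 37 mg/kg and sits within the usual scatter of compound 1 at 30 mg/kg so the two numbers cannot be ranked.

Compound 3 `CC(C)OC(=O)NC1=NC(c2ccccc2Cl)CN1C` is compound 2 with isopropyl in place of methyl on an oxygen next to a carbonyl group and it still awaits measurement in this assay as the next result.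

Within the data shown here, no measured pair shows this single change on its own, so the data offer no direct guide to its size. The only indirect hint comes from compound 1, which also carries isopropoxycarbonyl and gives 30 mg/kg in the same range as compound 2. No step beyond the scatter is therefore expected in either direction. The expected step of a 1.2-fold lower number from compound 2 to compound 3 (0.09 log units; within the scatter) is accordingly small. For compound 3 the estimate is 30 mg/kg with an expected range of 12 mg/kg to 75 mg/kg in this assay for now.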

Compound 3, dose for half-maximal effect: 29 mg/kg
Beside the measured number, compound 3's estimate is 1.0-fold (0.01 log units) above it, within the range that was stated.
By their numbers in this assay, from the lowest: compounds 3, 1 and 2 (each within the scatter of the next).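

With the chloro group held constant, this assay now gives a direct reading of isopropyl in place of methyl on an oxygen next to a carbonyl group: a 1.3-fold lower number from compound 2 to compound 3 (0.11 log units; within the scatter) leaves this change within the scatter. Among these compounds, with isopropoxycarbonyl held constant, the same result also gives the first reading of chloro in place of fluoro on an aromatic carbon, and a 1.0-fold lower number from compound 1 to compound 3 (0.01 log units; within the scatter) likewise stays within the scatter, so neither single change separates the compounds in these pairs. No evidence is available to explain either reading.

The compounds shown carry only methyl or isopropyl on this oxygen, which leaves open whether a longer chain such as n-butyl, or a benzyl group, would give a step beyond the scatter. On these data alone, on the aromatic carbon they carry only fluoro or chloro, so it also remains open how a bromo, methoxy or trifluoromethyl group would read on the shared core.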